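A Furan for a Thiophene, Starting From a Limit

The source may report more compounds than this note shows. Statements on the series, on what has been measured and on what is new or still open speak of the compounds shown alone.

Compound 1 `O=c1[nH]cnc2c1c(-c1cc3ccccc3o1)cn2[C@@H]1O[C@H](CO)[C@@H](O)[C@H]1O` gives > 20000 nM in a functional assay on HL-60 cells (Homo sapiens) for antiproliferative activity, read by XTT assay, with a stated time of 72 h (a lower number here means a stronger inhibitor, a higher number a weaker inhibitor), which is a limit of the assay rather than a number.
Compound 2 `O=c1[nH]cnc2c1c(-c1cccs1)cn2[C@@H]1O[C@H](CO)[C@@H](O)[C@H]1O` gives > 20000 nM in this assay, again a limit.
Compound 3 `Cc1nc(N)c2c(-c3ccsc3)cn([C@@H]3O[C@H](CO)[C@@H](O)[C@H]3O)c2n1` gives > 20000 nM in this assay, also a limit.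

Within the data shown here, every value here rests at the limit of > 20000 nM in this assay, at which 3 of the 3 values shown sit, so no compound has a measured strength at all. Among the measured compounds shown here, the one pair that differs in a single place, compound 1 and compound 2, therefore gives a step whose size cannot be read: a step that the two limits leave unreadable from compound 1 to compound 2. Compound 2 thus stands nowhere on a scale; it is known only to be weaker than the assay can report.

Compound 4 `O=c1[nH]cnc2c1c(-c1ccco1)cn2[C@@H]1O[C@H](CO)[C@@H](O)[C@H]1O` differs from compound 2 in one place: furan-2-yl in place of thiophen-2-yl on an aromatic carbon. For the measured compounds named here, no measured step tells what this change does, since the only step in the set is unreadable, and the two groups are counted alike in size, ring shape and hydrogen-bond acceptors. With nothing pointing to a gain, compound 4 is expected to stay at the limit as well, estimated at 30000 nM with a range from 8000 nM to 120000 nM. The expected step from compound 2 is therefore a step that the limit leaves unreadable from compound 2 to compound 4, not beyond the scatter.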

Compound 4, half-maximal inhibitory concentration: 2200 nM
For compound 4 the middle estimate is 14-fold (1.13 log units) above the measured one, outside the stated range (below it).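

In this assay, this aromatic carbon of the core turns out not to be a dead end: furan-2-yl in place of thiophen-2-yl gives an at least 9.0-fold lower number from compound 2 to compound 4 (0.95 log units; beyond the scatter). The two groups count alike in heavy atoms, ring type and hydrogen-bond acceptors, and the printed difference is the hetero atom, oxygen rather than sulfur, so even an exchange this small can separate a measurable compound from an unmeasurable one. The smaller furan-2-yl in place of 1-benzofuran-2-yl gives an at least 9.0-fold lower number from compound 1 to compound 4 (0.95 log units; beyond the scatter), and both steps are minimum sizes, since their starting points are limits: the limit of > 20000 nM in this assay, at which 3 of the 4 values shown sit.

As far as these compounds go, the true distance from compound 1 and compound 2 to compound 4 stays open, and the step between compound 1 and compound 2 cannot be read. Also open, from the compounds shown here alone, is whether an amine, a carboxylic acid or furan-3-yl on this carbon would give a measurable value.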